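This account rests on a few compounds, and the source may have more. Where it says the series, first, only, none or still open, it means among the compounds named here.

Measured so far:
- Compound 1, `Cc1ccc2cc(CN(Cc3ccc(F)cc3)C(=O)c3ccccc3)c(=O)[nH]c2c1`: > 33000 nM
- Compound 2, `Cc1ccc2[nH]c(=O)c(CN(Cc3ccc(OCC(=O)OC(C)(C)C)cc3)Cc3ccc(C(C)(C)C)cc3)cc2c1`: > 10000 nM

Both compounds share the same core and were tested in a toxicity assay on MDCK cells (Canis lupus familiaris) for cytotoxicity, read by crystal violet staining, with a stated time of 48 h; a higher number here means that more compound is tolerated, a lower number that less compound is tolerated. Compound 1 gave > 33000 nM, which is a limit of the assay rather than a number. Compound 2 gave > 10000 nM, which is likewise a limit and not a number. Compound 2 therefore stands where both values shown stand: at a limit, as the limit of > 10000 nM in this assay, at which 1 of the 2 values shown sits, states, and compound 1 sits at the limit of > 33000 nM in this assay, at which 1 of the 2 values shown sits.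

Compound 3, `Cc1ccc2[nH]c(=O)c(CN(Cc3ccc(OC(F)(F)F)cc3)Cc3ccc(C(C)(C)C)cc3)cc2c1`, has not yet been measured in this assay . It differs from compound 2 in one place: trifluoromethyl in place of (tert-butoxycarbonyl)methyl on an oxygen on an aromatic ring. Among the compounds with values here, no step between two measured compounds is available to guide this change, and neither measured value is a number. With both shown values at limits, no step beyond the scatter is expected in either direction in this assay , and compound 3 is also expected to be tolerated up to a limit. For compound 3 the estimate is 20000 nM, within a range from 8000 nM to 50000 nM, which means an expected step that the limit leaves unreadable from compound 2 to compound 3.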

Compound 3, half-maximal cytotoxic concentration: > 5000 nM
Compound 3: no number, only a limit (the forecaster's own chance of this, stated with the estimate: 75%); the middle value lies beyond the limit too.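

Compound 2 and compound 3 each give only a limit in this assay, not a number, and the step between them cannot be read. Still open, as far as these compounds go, are the actual half-maximal cytotoxic concentrations of compound 1, compound 2 and compound 3, and whether trifluoromethyl in place of (tert-butoxycarbonyl)methyl changes this read-out at all.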